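The source may hold more compounds than are shown below. What is called first, only, known or untested is meant among the compounds shown, and "the series" means these compounds.

Compound 2 `Cc1cccc(/C(N)=N/NC(=S)N2CCCCC2)n1` gives 63.2% in a functional assay on A-375 cells (Homo sapiens) for cytotoxicity, read by MTT assay, with a stated time of 72 h, tested at 3 uM; on this read-out lower numbers stand for less inhibition of growth and higher numbers for more inhibition of growth at the one concentration tested; compound 1 `Cc1cccc(/C(N)=N/NC(=S)N2CCSCC2)n1` gives 60.1%, and the difference between them, a number 3.1 percentage points higher from compound 1 to compound 2 (within the scatter), is one the assay cannot tell apart from noise. Compound 3 `Cc1cccc(/C(N)=N/NC(=S)N2CCCC2)n1` differs from compound 2 by pyrrolidin-1-yl in place of piperidin-1-yl on a thiocarbonyl carbon. Within the data shown here, the only measured step that bears on this exchange of one ring for another on a thiocarbonyl carbon is the one from compound 1 to compound 2, which stayed within the scatter. So no step beyond the scatter is expected in this assay. Compound 3 is therefore estimated at 60%, with a range from 45% to 75%, an expected step of a number 3.2 percentage points lower from compound 2 to compound 3 (within the scatter).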

Compound 3, percent growth inhibition at one concentration: 51.3%
For compound 3 the middle estimate is 8.7 percentage points above the measured one, within the range that was stated.
By their numbers in this assay, from the lowest: compounds 3, 1 and 2 (each within the scatter of the next, the first and the last beyond it).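

Swapping one ring for another on a thiocarbonyl carbon can move the result in this assay: pyrrolidin-1-yl in place of piperidin-1-yl gives a real, though modest, fall (a number 11.9 percentage points lower from compound 2 to compound 3 (beyond the scatter)). Pyrrolidin-1-yl in place of thiomorpholin-4-yl gives a step that stays within the scatter (a number 8.8 percentage points lower from compound 1 to compound 3 (within the scatter)), so only the first exchange is clearly resolved. Nothing available explains this fall. Still open, from the compounds shown here alone, is how a seven-membered azepan-1-yl ring or morpholin-4-yl, which has oxygen where thiomorpholin-4-yl has sulfur, would fare here. An open-chain dimethylamino group raises the same question.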